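The compounds below may be only part of what the source reports. "The series", "measured", "known", "first", "only" and "open" are said of these compounds alone.

Three analogues sharing one core have been measured in an ADME assay on MT4 cells (Homo sapiens) for cytotoxicity, read by MTT assay, with a stated time of 4 days; a higher number here means that more compound is tolerated, a lower number that less compound is tolerated. Compound 1 `Cc1cc(-c2ccccc2)cc(C)c1Nc1ccnc(Nc2ccc(C#N)cc2)n1` gives 4170 nM. Compound 2 `Cc1cc(-c2ccccc2C(F)(F)F)cc(C)c1Nc1ccnc(Nc2ccc(C#N)cc2)n1`, with trifluoromethyl in place of hydrogen on an aromatic carbon, gives 4210 nM. Compound 3 `Cc1cc(-c2ccc(C(F)(F)F)cc2)cc(C)c1Nc1ccnc(Nc2ccc(C#N)cc2)n1`, also with trifluoromethyl in place of hydrogen on an aromatic carbon, gives 4160 nM. Compound 3 stands level with the other two: the steps of a 1.0-fold lower number from compound 1 to compound 3 (0.00 log units; within the scatter) and a 1.0-fold lower number from compound 2 to compound 3 (0.01 log units; within the scatter) lie within the scatter, as does a 1.0-fold higher number from compound 1 to compound 2 (0.00 log units; within the scatter).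

Compound 4 `Cc1cc(-c2ccccc2Cl)cc(C)c1Nc1ccnc(Nc2ccc(C#N)cc2)n1` is not yet measured. Against compound 3 the change is 2-chlorophenyl in place of 4-(trifluoromethyl)phenyl on an aromatic carbon. Among the measured compounds shown here, the steps that bear on it are the three above, each flat, covering trifluoromethyl in place of hydrogen on an aromatic carbon twice over and 4-(trifluoromethyl)phenyl in place of 2-(trifluoromethyl)phenyl on an aromatic carbon. No change in this series has moved the read-out beyond the scatter. Chlorine itself has not been tried, so this step rests on analogy only. The expectation for compound 4 is accordingly no step beyond the scatter, a 1.0-fold higher number from compound 3 to compound 4 (0.00 log units; within the scatter). Compound 4 is estimated at 4200 nM, with a range from 2100 nM to 8400 nM.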

Compound 4, half-maximal cytotoxic concentration: 3990 nM
The estimate for compound 4 lay 1.1-fold (0.02 log units) above the measured number; the measured number falls inside the stated range.
By their numbers in this assay, from the lowest: compounds 4, 3, 1 and 2 (each within the scatter of the next).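

In this assay chlorine now joins trifluoromethyl as a substituent on this aryl group without any step leaving the scatter: chloro in place of hydrogen gives a 1.0-fold lower number from compound 1 to compound 4 (0.02 log units; within the scatter) and chloro in place of trifluoromethyl gives a 1.1-fold lower number from compound 2 to compound 4 (0.02 log units; within the scatter) on the same ring position. Replacing the whole 4-(trifluoromethyl)phenyl of 10 heavy atoms with 2-chlorophenyl of 7 also stays flat, at a 1.0-fold lower number from compound 3 to compound 4 (0.02 log units; within the scatter) for this exchange, so neither the substituent nor the size of the entering group separates these four compounds. No available measurement explains this flatness.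

The shown substituents are limited to hydrogen, chloro and trifluoromethyl, so an amine, a carboxylic acid or a hydroxyl on this phenyl remains open. Also open, from the compounds shown here alone, is whether a longer alkyl chain in place of the phenyl would step beyond the scatter in this assay for this series.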